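Replacing 2,6-dimethoxyphenyl with 2,4-dichlorophenyl: an estimate

A few compounds are considered here, and "the series" means these few. Any claim that something is new, unique, unknown or untested is made for them only; others in the source may bear on it.

Among the measured compounds shown here, in a functional assay on KM12 cells (Homo sapiens) for inhibition, read by sulforhodamine B assay, with a stated time of 48 h (a higher number here means a weaker inhibitor of growth, a lower number a stronger inhibitor of growth), compound 1 `O=C(Cc1csc2nc(-c3ccc(Br)cc3)cn12)N/N=C/c1ccccc1` reads 26300 nM and compound 2 `COc1cccc(OC)c1/C=N/NC(=O)Cc1csc2nc(-c3ccc(Br)cc3)cn12` reads 8910 nM as the lower of the two numbers so far, which makes it the stronger inhibitor of growth. Compound 3 `O=C(Cc1csc2nc(-c3ccc(Br)cc3)cn12)N/N=C/c1ccc(Cl)cc1Cl` has 2,4-dichlorophenyl in place of 2,6-dimethoxyphenyl on a carbon with a double bond to nitrogen and keeps the rest of the structure. For the measured compounds named here, only one measured step bears on this place: a 3.0-fold lower number from compound 1 to compound 2 (0.47 log units; beyond the scatter) came with 2,6-dimethoxyphenyl in place of phenyl, and it was modest. Going by the values given here, no measured compound carries chlorine, so that step gives a rough size but no direction. In this assay no change beyond the scatter is therefore expected, and the estimate means a 1.2-fold higher number from compound 2 to compound 3 (0.09 log units; within the scatter) as a small step. For compound 3 the estimated value is 11000 nM with a range of 3000 nM to 35000 nM as the expected span.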

Compound 3, concentration for 50% growth inhibition: 38000 nM
Estimate against measurement, compound 3: 3.5-fold (0.54 log units) below; measured number above the stated range.
By their numbers in this assay, from the lowest: compound 2; then compounds 1 and 3 (each within the scatter of the next).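

In this assay the swap gives a 4.3-fold higher number from compound 2 to compound 3 (0.63 log units; beyond the scatter) and so shows that the gain seen with 2,6-dimethoxyphenyl does not extend to every substituted phenyl on this carbon with a double bond to nitrogen. Set against plain phenyl, 2,4-dichlorophenyl gives a 1.4-fold higher number from compound 1 to compound 3 (0.16 log units; within the scatter) and cannot be told apart from it, which leaves 2,6-dimethoxyphenyl as the only one of these three groups that stands out. No evidence at hand explains the gap between the two substituted phenyl groups.

The compounds shown leave open whether the difference follows the kind of group or the places it occupies on the ring, a question that 2,4-dimethoxyphenyl and 2,6-dichlorophenyl would separate. As far as these compounds go, it also remains open how a phenyl carrying a hydroxyl or an amine would compare.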